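This account rests on a few compounds, and the source may have more. Where it says the series, first, only, none or still open, it means among the compounds named here.

Compound 1 `CCOc1ccc(C2CC2C(=O)NNC(=O)c2ccncc2)cc1`: "not determined" (no result reported) in a functional assay on SK-MEL cells (Homo sapiens) for inhibition, read by MTT assay, with a stated time of 72 h; on this read-out lower numbers stand for stronger inhibition and higher numbers for weaker inhibition
Compound 2 `COc1ccc(C2CC2C(=O)NNc2nncc3ccccc23)cc1`: 68000 nM

In this assay, among the compounds with values here, compound 2 gives 68000 nM, the only number there is, so it stands alone; compound 1 gives nothing to compare with. Compound 3 `CC(C)=CCC/C(C)=C/COc1ccc(C2CC2C(=O)NNc2nncc3ccccc23)cc1` differs from compound 2 by 2,6-dimethylhepta-1,5-dien-1-yl in place of hydrogen on a saturated chain carbon bound to an oxygen on an aromatic ring. Without any measured step to lean on, only a guess is possible. For compound 3 the step of a 3.4-fold lower number from compound 2 to compound 3 (0.53 log units; beyond the scatter) is expected to run toward stronger inhibition, beyond the usual scatter but not by a large margin. Compound 3 is therefore estimated at 20000 nM, within a range from 5000 nM to 80000 nM.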

Compound 3, half-maximal inhibitory concentration: 25000 nM
Compound 3: middle estimate off by 1.3-fold (0.10 log units), on the low side; low and high end bracket the measured number.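

Going from the methoxy group to the (3,7-dimethylocta-2,6-dien-1-yl)oxy group gives a 2.7-fold lower number from compound 2 to compound 3 (0.43 log units; beyond the scatter) in this assay. This position therefore accepts a much larger, ring-free chain without losing inhibition, and the number even improves modestly. Nothing available explains this step.

As far as these compounds go, whether the change depends on the chain's length or on its double bonds remains open, and a saturated octyl chain would separate the two. How a terminal amine or carboxylic acid on the chain would behave is also unknown.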